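From ring to carboxy at one aromatic carbon

The source may hold more compounds than are shown below. What is called first, only, known or untested is meant among the compounds shown, and "the series" means these compounds.

Measured so far in a physicochemical assay for acid dissociation 

- Compound 1 `CCc1nc2c(C)cc(C)nc2n1Cc1ccc(-c2ccccc2C2=NOS(=O)N2)cc1` at 5.7 
- Compound 2 `CCc1nc2c(C)cc(C)nc2n1Cc1ccc(-c2ccccc2C2Nc3cc(Cl)c(S(N)(=O)=O)cc3S(=O)(=O)N2)cc1` at 8.9 

Of these two numbers, compound 1 holds the lowest, and compound 2 stands above it by a gap beyond the scatter. The two compounds do not differ in a way that gives a single-place step to reason from.

Compound 3 `CCc1nc2c(C)cc(C)nc2n1Cc1ccc(-c2ccccc2C(=O)O)cc1` departs from compound 1 in one place, on an aromatic carbon of a six-membered aromatic ring of carbon only, ortho to a large group. There, carboxy takes the place of the group with one five-membered non-aromatic ring with 4 hetero atoms (a group of 3 heavy atoms (1 carbon, 2 oxygen; no ring) in place of a group of 6 heavy atoms (1 carbon, 2 nitrogen, 2 oxygen, 1 sulfur; one five-membered non-aromatic ring with 4 hetero atoms), on an aromatic carbon). Among the compounds with values here, no measured step of this kind exists, so the expectation rests on this change and on compound 1 at 5.7 as its starting point. The expected step of a number 1.40 log units lower from compound 1 to compound 3 (beyond the scatter) is downward and beyond the scatter. In this assay compound 3 is expected at 4.3 with an estimated range from 3.6 to 5 until a measurement settles it.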

Compound 3, acid dissociation constant: 5.1
Compound 3: middle estimate off by 0.80 log units, on the low side; measured number above the stated range.
By their numbers in this assay, from the lowest: compound 3; then compound 1; then compound 2.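

In this assay, with carboxy on the aromatic carbon ortho to a large group in place of the group with one five-membered non-aromatic ring with 4 hetero atoms, the reading comes out a number 0.60 log units lower from compound 1 to compound 3 (beyond the scatter). Within the data shown here, this is the first single-place step in the set, and it shows that this place responds to a change of group. It also shows that the ring can give way to an open group of 3 heavy atoms with only a modest move in the read-out. Nothing at hand accounts for the size or direction of this step.

Going by these compounds, it remains open where other groups on this aromatic carbon, such as a tetrazole or an acylsulfonamide, would fall on this scale. Also open, on these data alone, is whether the same exchange would give a similar step if the shared core carried a longer chain.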